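Adding a Methyl to the Lactone Ring of Compound 1

This account rests on a few compounds, and the source may have more. Where it says the series, first, only, none or still open, it means among the compounds named here.

Measured compounds:
- compound 1, `C=C/C=C\[C@H](C)[C@H](OC(N)=O)[C@@H](C)[C@H](O)[C@@H](C)C/C(C)=C\[C@H](C)[C@@H](O)[C@@H](C)/C=C\[C@@H](O)C[C@@H]1OC(=O)C=C[C@H]1C`: 3.7 nM
- compound 2, `C=C/C=C\[C@H](C)[C@H](OC(N)=O)[C@@H](C)[C@H](O)[C@@H](C)C/C=C\[C@H](C)[C@@H](O)[C@@H](C)/C=C\[C@@H](O)C[C@@H]1OC(=O)[C@H](C)[C@@H](O)[C@H]1C`: 50 nM

Of the compounds shown here, two have been measured in a functional assay on the whole organism (A549 cells, Mus musculus) for inhibition, with A549 (Homo sapiens) as the target; a higher number here means a weaker inhibitor, a lower number a stronger inhibitor. Compound 1 gives 3.7 nM, the lower of the two numbers, and compound 2 gives 50 nM, a gap that lies beyond the scatter of repeated measurements. Compound 1 therefore stands as the stronger inhibitor of the pair.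

Compound 3, `C=C/C=C\[C@H](C)[C@H](OC(N)=O)[C@@H](C)[C@H](O)[C@@H](C)C/C(C)=C\[C@H](C)[C@@H](O)[C@@H](C)/C=C\[C@@H](O)C[C@@H]1OC(=O)C(C)=C[C@H]1C`, has not yet been measured in this assay. It differs from compound 1 in one place: methyl in place of hydrogen on a double-bonded ring carbon. Among the measured compounds shown here, the two compounds measured so far do not share a single-point change, so no directly comparable step exists to lean on. A single added methyl on the ring is a small change, and the expected step of a 1.6-fold higher number from compound 1 to compound 3 (0.21 log units; within the scatter) is small, with no clear direction beyond the scatter. Compound 3 is therefore estimated to give 6 nM in this assay, within a range of 2 nM to 25 nM.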

Compound 3, half-maximal inhibitory concentration: 8.6 nM
For compound 3 the middle estimate is 1.4-fold (0.16 log units) below the measured one, and the stated range covers the measured number.
By their numbers in this assay, from the lowest: compound 1; then compound 3; then compound 2.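

In this assay, methyl in place of hydrogen on a double-bonded ring carbon brings a 2.3-fold higher number from compound 1 to compound 3 (0.37 log units; beyond the scatter). Among the compounds shown here, this is the first change in the set made at a single place, and it shows that this ring carbon, two ring bonds from the ring oxygen, accepts a methyl at a modest cost in strength, so the position is not indifferent to what sits on it. Nothing available here gives a reason for this step.

Going by these compounds, whether a longer chain, such as ethyl, would raise the number further at this carbon remains open, as does the effect of a different kind of group there, such as an amine or a carboxylic acid. One step also cannot tell whether the same methyl would cost as much on a different core.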